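Para substituent swap on the aryl ketone

A few compounds are considered here, and "the series" means these few. Any claim that something is new, unique, unknown or untested is made for them only; others in the source may bear on it.

Compound 2 `O=C(/C=C/c1cc2ccccc2[nH]c1=O)c1ccc(O)cc1` gives 3870 nM in a functional assay on UACC-257 cells (Homo sapiens) for cytotoxicity, read by sulforhodamine B assay, with a stated time of 24 h; a lower number here means a stronger inhibitor of growth, a higher number a weaker inhibitor of growth; compound 1 `COc1ccc(C(=O)/C=C/c2cc3ccccc3[nH]c2=O)cc1` gives 4900 nM in this assay, and the two sit within the scatter of each other, as the step of a 1.3-fold lower number from compound 1 to compound 2 (0.10 log units; within the scatter) shows. Compound 3 `O=C(/C=C/c1cc2ccccc2[nH]c1=O)c1ccc(Cl)cc1` carries chloro in place of hydroxy on an aromatic carbon. Going by the values given here, the one measured step concerns a methyl against a hydrogen on the oxygen, not the replacement of the hydroxy itself, so it bears on compound 3 only loosely; no step beyond the scatter is expected. For compound 3 the expected step is a 1.1-fold lower number from compound 2 to compound 3 (0.04 log units; within the scatter). Compound 3 is estimated at 3500 nM in this assay, between 1200 nM and 10000 nM.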

Compound 3, concentration for 50% growth inhibition: 7780 nM
Estimate against measurement, compound 3: 2.2-fold (0.35 log units) below, and the stated range covers the measured number.
By their numbers in this assay, from the lowest: compounds 2, 1 and 3 (each within the scatter of the next).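

Going by these compounds alone, compound 3 is the first replacement of the oxygen itself on the 4-hydroxyphenyl group, and both a 2.0-fold higher number from compound 2 to compound 3 (0.30 log units; within the scatter) and a 1.6-fold higher number from compound 1 to compound 3 (0.20 log units; within the scatter) are within the scatter. Chloro, with 0 hydrogen-bond donors and 0 hydrogen-bond acceptors, therefore cannot be told apart in this assay from hydroxy or methoxy at this place, para to a large group. Nothing at hand explains this result.

Open, on these data alone, is whether any group here gives a step beyond the scatter, for example an amine, a carboxylic acid or a longer chain. Also open, as far as these compounds go, is whether the same swaps read alike in other cells.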